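Moving the chlorine on the aryl ring of compound 3

A few compounds are considered here, and "the series" means these few. Any claim that something is new, unique, unknown or untested is made for them only; others in the source may bear on it.

Measured in a functional assay on MCF7 cells (Homo sapiens) for cytotoxicity, read by MTT assay, with a stated time of 72 h; a higher number here means a weaker inhibitor, a lower number a stronger inhibitor:
- compound 1 `COc1cccc(/C=C2\CCC/C(=C\c3ccc(Cl)cc3)C2=O)c1OC`: 10300 nM
- compound 2 `COc1cccc(/C=C2\CCC/C(=C\c3cc(Cl)cc(Cl)c3)C2=O)c1OC`: 4300 nM
- compound 3 `COc1ccc(/C=C2\CCC/C(=C\c3ccccc3Cl)C2=O)cc1OC`: 10400 nM

Compound 3 stands at the high end of these numbers, although its value lies within the scatter of that of compound 1. Compound 2 gives a lower number, and that gap is beyond the scatter. Compound 4 `COc1ccc(/C=C2\CCC/C(=C\c3cccc(Cl)c3)C2=O)cc1OC` keeps the atoms of compound 3 but joins them differently: 3-chlorophenyl in place of 2-chlorophenyl on a double-bonded chain carbon bound to a double-bonded ring carbon. Among the compounds with values here, only one measured step bears on this change, a 2.4-fold lower number from compound 1 to compound 2 (0.38 log units; beyond the scatter). It falls at the same place and is modest, but it alters the chlorine count and has a different substitution on the other side of the shared core. Within the data shown here, no measured step shows a single chlorine moving with all else fixed. In this assay, therefore, no shift beyond the scatter is expected, with only a slight lean towards a lower number. The expected change is a 1.3-fold lower number from compound 3 to compound 4 (0.11 log units; within the scatter). For compound 4 the estimated value is 8000 nM, with an expected range of 3500 nM to 18000 nM.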

Compound 4, half-maximal inhibitory concentration: 6000 nM
Compound 4: the middle estimate sits 1.3-fold (0.12 log units) above what was measured, and the stated range covers the measured number.
By their numbers in this assay, from the lowest: compounds 2, 4, 1 and 3 (each within the scatter of the next, the first and the last beyond it).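

In this assay the result gives the first view of a single chlorine moving with all else fixed: 3-chlorophenyl in place of 2-chlorophenyl on a double-bonded chain carbon bound to a double-bonded ring carbon gives a 1.7-fold lower number from compound 3 to compound 4 (0.24 log units; within the scatter) and so stays inside the usual variation. The only earlier step at this place, a 2.4-fold lower number from compound 1 to compound 2 (0.38 log units; beyond the scatter), changed the chlorine count and lay beyond the scatter, so among these compounds only that step, and not the moved chlorine, gives a shift beyond it. Nothing measured here bears on why the step has this size.

Going by these compounds, it remains open whether the same chlorine move would behave alike with the other side of the shared core as in compound 1. On these data alone, it is also open how an amine or a nitrile on this aryl ring would compare with the chlorine.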